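Swapping the aryl ketone ring: methoxy to difluoro

This account rests on a few compounds, and the source may have more. Where it says the series, first, only, none or still open, it means among the compounds named here.

Measured so far in a functional assay on SF-268 cells (Homo sapiens) for inhibition, read by sulforhodamine B assay, with a stated time of 48 h; on this read-out lower numbers stand for stronger inhibition of growth and higher numbers for weaker inhibition of growth:
compound 1 `COc1ccc(C(=O)/C=C/c2cc(-c3cc(OC)c(OC)c(OC)c3)n[nH]2)cc1OC` gives 3960 nM
compound 2 `COc1ccc(C(=O)/C=C/c2cc(-c3cc(OC)c(OC)c(OC)c3)n[nH]2)cc1` gives 5120 nM

Of these two numbers, compound 2 has the higher one; its nearest neighbour is compound 1, with a 1.3-fold higher number from compound 1 to compound 2 (0.11 log units; within the scatter). Compound 3 `COc1cc(-c2cc(/C=C/C(=O)c3ccc(F)c(F)c3)[nH]n2)cc(OC)c1OC` is not yet measured. It differs from compound 2 by 3,4-difluorophenyl in place of 4-methoxyphenyl on a carbonyl carbon. Within the data shown here, only one measured step bears on this change, a 1.3-fold higher number from compound 1 to compound 2 (0.11 log units; within the scatter), and it replaced a methoxy with hydrogen on an aromatic carbon without moving the number beyond the scatter. Among the measured compounds shown here, no measured compound carries fluorine, so the effect of the difluoro ring is unknown. The step is therefore expected to be a 1.2-fold higher number from compound 2 to compound 3 (0.07 log units; within the scatter). Compound 3 is estimated at 6000 nM, with a range from 2500 nM to 15000 nM.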

Compound 3, concentration for total growth inhibition: > 100000 nM
Compound 3 was reported as a limit (the forecaster's own chance of this, stated with the estimate: 10%); middle value at least 16-fold (1.22 log units) away from the limit.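

In this assay compound 3 gives > 100000 nM, which is a limit of the assay and not a number. Changing the ring on the carbonyl carbon can therefore matter far more than the earlier step suggested: removing one methoxy gave only a 1.3-fold higher number from compound 1 to compound 2 (0.11 log units; within the scatter), whereas the difluoro ring gave an at least 19-fold higher number from compound 2 to compound 3 (1.29 log units; beyond the scatter) and an at least 25-fold higher number from compound 1 to compound 3 (1.40 log units; beyond the scatter). This position accepts 4-methoxyphenyl and 3,4-dimethoxyphenyl alike, but 3,4-difluorophenyl brings a large loss of growth inhibition.

Still open, going by these compounds, is whether the fluorines or the absence of any methoxy on this ring drives that loss. Plain phenyl, or phenyl carrying a dimethylamino group, would help separate the two.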